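Replacing the pyridyl arm of compound 1 with a trifluoromethyl ketone

The source may hold more compounds than are shown below. What is called first, only, known or untested is meant among the compounds shown, and "the series" means these compounds.

Measured compounds:
compound 1, `COC(=O)c1ccc(-c2cnc(C(=O)CCc3ccc(-c4ccccc4)cc3)o2)nc1`, 2.2 nM
compound 2, `O=C(O)c1cccc(-c2cnc(C(O)CCc3ccc(-c4ccccc4)cc3)o2)n1`, 1100 nM
compound 3, `O=C(CCc1ccc(COc2ccccc2)cc1)c1ncco1`, 25 nM

The three values come from an assay for inhibition of Fatty-acid amide hydrolase 1 (Rattus norvegicus); a higher number here means a weaker inhibitor, a lower number a stronger inhibitor. Compound 1 has the lowest number of the three, and both gaps lie beyond the scatter: compound 3 stands nearer to it, compound 2 much farther away. Compound 1 is thus the strongest inhibitor in this set. Compound 2 and compound 3 each differ from compound 1 in more than one place, so their values show only where they stand, not what any single change does.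

The unmeasured compound 4 is `O=C(CCc1ccc(-c2ccccc2)cc1)c1ncc(C(=O)C(F)(F)F)o1`. It differs from compound 1 by (trifluoromethyl)carbonyl in place of 5-(methoxycarbonyl)pyridin-2-yl on an aromatic carbon. Within the data shown here, no single-change step between measured compounds is available to calibrate this exchange, so the expectation rests on how far compound 1 sits from compound 3, whose unsubstituted core carries a different tail. A modest step towards a higher number is expected, somewhat beyond the scatter, as a 3.6-fold higher number from compound 1 to compound 4 (0.56 log units; beyond the scatter). Compound 4 is therefore estimated at 8 nM, within a range from 2 nM to 40 nM.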

Compound 4, inhibition constant: 8 nM
For compound 4 middle estimate and measured number coincide at the digits printed, and the stated range covers the measured number.
By their numbers in this assay, from the lowest: compound 1; then compound 4; then compound 3; then compound 2.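

In this assay, the exchange at this position, on the aromatic carbon next to the ring oxygen, gives a 3.6-fold higher number from compound 1 to compound 4 (0.56 log units; beyond the scatter), a modest step that lies beyond the scatter. It shows that this position does not depend on the six-membered aromatic ring for strong inhibition: compound 4, whose (trifluoromethyl)carbonyl has no ring and fewer heavy atoms than the group it replaces, still gives 8 nM, although some inhibition is lost. No measurement here bears on why the step has this size, so the result remains a description of the change and offers no explanation for it.

The exchange removes the pyridine ring and the methyl ester together, so the compounds shown leave open how much of the step belongs to each part, a question that a plain pyridin-2-yl group on the same carbon would address. They also leave open whether the three fluorines matter, which could be tested by comparing compound 4 with its acetyl counterpart, and whether other small groups, such as a nitrile or a carboxylic acid, would be accepted at this position.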